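Swapping a tolyl for a chlorophenyl on a serotonin ligand

The compounds below may be only part of what the source reports. "The series", "measured", "known", "first", "only" and "open" are said of these compounds alone.

Measured compounds:
compound 1, `c1ccc(Cn2cc(-c3ccccc3)c3c2CCNC3)cc1`, 220 nM
compound 2, `Clc1ccc(-c2cn(Cc3ccccc3)c3c2CNCC3)c(Cl)c1`, 2070 nM
compound 3, `Cc1ccc(-c2cn(Cc3ccccc3)c3c2CNCC3)cc1`, 35 nM

In an assay on HEK293 cells for displacement of a labelled ligand from 5-hydroxytryptamine receptor 7 (Rattus norvegicus), with a stated time of 60 min (a higher number here means a weaker inhibitor, a lower number a stronger inhibitor), compound 3 gives 35 nM, the lowest number of the three, so it is the strongest inhibitor among them. Compound 1 gives 220 nM and compound 2 gives 2070 nM. The steps are clear: a 6.3-fold lower number from compound 1 to compound 3 (0.80 log units; beyond the scatter), and a 9.4-fold higher number from compound 1 to compound 2 (0.97 log units; beyond the scatter), so that a 59-fold lower number from compound 2 to compound 3 (1.77 log units; beyond the scatter).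

Compound 4, `Clc1cccc(-c2cn(Cc3ccccc3)c3c2CNCC3)c1`, is not yet measured. It differs from compound 3 by 3-chlorophenyl in place of 4-methylphenyl on an aromatic carbon. Among the compounds with values here, two measured steps bear on this: removing the methyl, as seen in the step from compound 3 back to compound 1, costs potency, and placing chlorines on the ring, as in the step from compound 1 to compound 2, costs further. A single chlorine is a smaller change than two, so compound 4 is expected to land between compound 1 and compound 2 in this assay. The estimate for compound 4 is therefore 250 nM, with a range from 70 nM to 900 nM, which would mean an expected step of a 7.1-fold higher number from compound 3 to compound 4 (0.85 log units; beyond the scatter).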

Compound 4, inhibition constant: 10000 nM
Compound 4: the middle estimate sits 40-fold (1.60 log units) below what was measured; measured number above the stated range.
By their numbers in this assay, from the lowest: compound 3; then compound 1; then compound 2; then compound 4.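

In this assay, chlorine on this ring does not act by degree: 3-chlorophenyl, with a single chlorine, is the weakest binder of the four, showing a 45-fold higher number from compound 1 to compound 4 (1.66 log units; beyond the scatter) and also a 4.8-fold higher number from compound 2 to compound 4 (0.68 log units; beyond the scatter). One chlorine is therefore not simply a smaller version of the 2,4-dichlorophenyl change. The swap also gives a 290-fold higher number from compound 3 to compound 4 (2.46 log units; beyond the scatter), even though the entering and leaving groups have the same heavy-atom count, so that count alone does not set the result here, and no measurement at hand explains the drop.

As far as these compounds go, whether the loss follows the chlorine itself or the place it occupies on the ring remains open. A 4-chlorophenyl or a 3-methylphenyl at this position would separate those two readings.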